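Cytotoxicity of the benzoyl-pyrrole boronate series: compound 4

The source may report more compounds than this note shows. Statements on the series, on what has been measured and on what is new or still open speak of the compounds shown alone.

Compound 1 `O=C(c1ccn(-c2ccc3c(c2)B(O)OC3)c1)c1ccccc1Cl`, compound 2 `CC(=O)OCc1ccc(C(=O)c2ccn(-c3ccc4c(c3)B(O)OC4)c2)cc1` and compound 3 `O=C(c1ccc(CO)cc1)c1ccn(-c2ccc3c(c2)B(O)OC3)c1` share one core and differ only in the aryl group on the carbonyl carbon. In an ADME assay on L929 cells (Mus musculus) for cytotoxicity, read by resazurin assay, with a stated time of 72 h (a higher number here means a weaker inhibitor, a lower number a stronger inhibitor), compound 1 gives > 10 ug/mL, which is a limit of the assay and not a number. In this assay compound 2 gives 10 ug/mL and compound 3 gives 9.31 ug/mL; compound 3 holds the lowest of the two numbers, and the gap to compound 2 is within the scatter. The two steps into compound 3 are small: an at least 1.0-fold lower number from compound 1 to compound 3 (0.03 log units; that floor lies within the scatter) and a 1.1-fold lower number from compound 2 to compound 3 (0.03 log units; within the scatter).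

Compound 4 `O=C(c1ccc(O)cc1)c1ccn(-c2ccc3c(c2)B(O)OC3)c1` differs from compound 3 by hydroxy in place of hydroxymethyl on an aromatic carbon. For the measured compounds named here, no measured step repeats this exact change, but both measured changes at the same aryl position left this assay within the scatter, so no step beyond the scatter is expected, in either direction; the values cluster near the limit (the limit of > 10 ug/mL in this assay, at which 1 of the 3 values shown sits). Compound 4 is therefore estimated at 10 ug/mL, between 5 ug/mL and 20 ug/mL, meaning an expected step of a 1.1-fold higher number from compound 3 to compound 4 (0.03 log units; within the scatter).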

Compound 4, half-maximal inhibitory concentration: > 10 ug/mL
Compound 4: only a limit was reported; the forecaster's own chance of this, stated with the estimate: 40%; the middle value sits exactly at the limit.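

Going from hydroxymethyl to hydroxy on this aromatic carbon, para to a large group, gives an at least 1.0-fold higher number from compound 3 to compound 4 (0.03 log units; that floor lies within the scatter) in this assay. This adds a third change at the aryl position; the value of compound 4 is a limit of the assay and not a number, so only the floor of this step lies within the scatter. The change from acetoxymethyl to hydroxy gives a number no lower from compound 2 to compound 4 (the limit leaves the size open). The step to compound 4 from compound 1 cannot be read, and the limit now constrains what this position can show: the limit of > 10 ug/mL in this assay, at which 2 of the 4 values shown sit.

The compounds shown leave open whether an amine, a carboxylic acid or a longer chain ending in hydroxy at this position would move the number in this assay beyond the scatter. Going by these compounds, whether a change on the shared core, away from this aryl group, would do so also remains open.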